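Methoxy in place of isopropyl on the aryl nitrogen substituent

The source may hold more compounds than are shown below. What is called first, only, known or untested is meant among the compounds shown, and "the series" means these compounds.

compound 1, `COc1ccc(-c2nc(CNc3ccc(C(=O)NO)cc3)n(-c3ccccc3)n2)cc1`: 77.6%
compound 2, `Cc1cccc(-n2nc(-c3ccccc3)nc2CNc2ccc(C(=O)NO)cc2)c1`: 66%
compound 3, `CC(C)c1ccc(-n2nc(-c3ccccc3)nc2CNc2ccc(C(=O)NO)cc2)cc1`: 52.6%

All three were tested in an assay on Sf9 cells for inhibition of protein deacetylase HDAC6 (Homo sapiens), read by fluorescence, with a stated time of 40 min, tested at 100 nM; on this read-out higher numbers stand for more inhibition at the one concentration tested (going by the name of the read-out) and lower numbers for less inhibition. Compound 3 stands lowest of the three numbers; compound 2 lies above it by a step beyond the scatter, and compound 1 lies further above it, also beyond the scatter. Among the measured compounds shown here, the one step that changes the aryl group on the aromatic nitrogen is a number 13.4 percentage points lower from compound 2 to compound 3 (beyond the scatter).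

Compound 4, `COc1ccc(-n2nc(-c3ccccc3)nc2CNc2ccc(C(=O)NO)cc2)cc1`, differs from compound 3 in one place: methoxy in place of isopropyl on an aromatic carbon. For the measured compounds named here, no measured step exchanges isopropyl for methoxy on this ring, so the only bearing comes from the single modest downward step a number 13.4 percentage points lower from compound 2 to compound 3 (beyond the scatter), which shows that the aryl group on the nitrogen can move the read-out by a modest amount. Compound 1 carries methoxy elsewhere and gives no direct guide. A modest rise is therefore expected, not larger than that earlier step. The step from compound 3 to compound 4 is expected to be a number 9.4 percentage points higher from compound 3 to compound 4 (within the scatter). Compound 4 is estimated at 62%, with a range from 45% to 78%.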

Compound 4, a percentage reported as inhibition, at one concentration (the size of the read-out at that concentration, not a potency): 63.4%
Compound 4: middle estimate off by 1.4 percentage points, on the low side; the measured number falls inside the stated range.
By their numbers in this assay, from the lowest: compound 3; then compounds 4 and 2 (each within the scatter of the next); then compound 1.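

In this assay, putting 4-methoxyphenyl in place of 4-isopropylphenyl on the aromatic nitrogen gives a number 10.8 percentage points higher from compound 3 to compound 4 (beyond the scatter), the first direct sign that the group on this aromatic carbon itself moves the read-out. The change from the 3-methylphenyl group gives a number 2.6 percentage points lower from compound 2 to compound 4 (within the scatter), so these two aryl groups cannot be told apart here, and the lower number of compound 3 is not shared by the methoxy analogue. No supporting data bear on why the exchange raises the number.

Going by these compounds, it remains open how a hydroxyl, an amine or a longer chain such as butoxy would read at this place. A single concentration also leaves open whether these differences would hold across a full range of concentrations.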